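Swapping a chlorophenyl for a nitrophenyl on a weak core

The source may hold more compounds than are shown below. What is called first, only, known or untested is meant among the compounds shown, and "the series" means these compounds.

Of the compounds shown here, three with a shared core have been tested in a functional assay on MCF7 cells (Homo sapiens) for cytotoxicity, read by MTT assay, with a stated time of 24 h; on this read-out higher numbers stand for weaker inhibition and lower numbers for stronger inhibition. Compound 2 `COc1ccccc1N1CCN(CC(=O)N2CCN(c3nnc(-c4ccc(C)cc4)c(-c4ccc(C)cc4)n3)CC2)CC1` gives 59400 nM in this assay. Compound 3 `Cc1ccc(-c2nnc(N3CCN(C(=O)CN4CCN(c5cccc(Cl)c5)CC4)CC3)nc2-c2ccc(C)cc2)cc1` gives 797000 nM in this assay; the change between them is a 13-fold higher number from compound 2 to compound 3 (1.13 log units; beyond the scatter), so compound 3 stands highest of the two numbers shown, with compound 2 as its only numerical neighbour. Compound 1 `O=C(CN1CCN(c2ccc([N+](=O)[O-])cc2)CC1)N1CCN(c2nnc(-c3ccccc3)c(-c3ccccc3)n2)CC1` gives > 886000 nM in this assay, and that value is a limit of the assay rather than a number, (the limit of > 886000 nM in this assay, at which 1 of the 3 values shown sits).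

Compound 4 `Cc1ccc(-c2nnc(N3CCN(C(=O)CN4CCN(c5ccc([N+](=O)[O-])cc5)CC4)CC3)nc2-c2ccc(C)cc2)cc1` has not yet been measured. It differs from compound 3 by 4-nitrophenyl in place of 3-chlorophenyl on an amine nitrogen in a ring. Within the data shown here, no measured step covers this exact exchange. Among the measured compounds shown here, the one measured step, a 13-fold higher number from compound 2 to compound 3 (1.13 log units; beyond the scatter), shows that changing the group on this ring nitrogen can shift the number strongly. Compound 1 carries the same 4-nitrophenyl at this place, and its value is a limit. Compound 4 is therefore expected to stay very weak, with a 1.1-fold higher number from compound 3 to compound 4 (0.03 log units; within the scatter) expected. The estimate for compound 4 is 850000 nM, with a range from 300000 nM to 2500000 nM.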

Compound 4, half-maximal inhibitory concentration: 845000 nM
Beside the measured number, compound 4's estimate is 1.0-fold (0.00 log units) above it, and the stated range covers the measured number.
By their numbers in this assay, from the lowest: compound 2; then compounds 3 and 4 (each within the scatter of the next). At a limit, above all of these: compound 1.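

In this assay, exchanging the 3-chlorophenyl for the 4-nitrophenyl on this ring nitrogen gives a 1.1-fold higher number from compound 3 to compound 4 (0.03 log units; within the scatter), so these two groups cannot be told apart here. The comparison with the 2-methoxyphenyl gives a 14-fold higher number from compound 2 to compound 4 (1.15 log units; beyond the scatter), which means that a second group on the shared core now reads far from compound 2, and compound 2 is the only one of these three that stands apart. Compound 1 carries the same 4-nitrophenyl on its own core, but its value is a limit and gives no step here: the limit of > 886000 nM in this assay, at which 1 of the 4 values shown sits.

The compounds shown leave open whether the methoxy group itself matters or where it sits on the phenyl ring, a question that a 4-methoxyphenyl or a plain phenyl at this nitrogen could address. Going by these compounds, how a simple alkyl chain in place of the aromatic ring would read also remains open.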